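Swapping carbamoyl for amino in an antiproliferative series

The source may report more compounds than this note shows. Statements on the series, on what has been measured and on what is new or still open speak of the compounds shown alone.

Three measured compounds share one core and differ in a single group on an aromatic ring. In a functional assay on KB cells (nasopharynx, Homo sapiens) for antiproliferative activity (a higher number here means a weaker inhibitor, a lower number a stronger inhibitor), compound 1 `COc1ccc(S(=O)(=O)Nc2cccc3c(C#N)c[nH]c23)cc1`, which carries methoxy, gives 1.4 ug/mL. Compound 3 `N#Cc1c[nH]c2c(NS(=O)(=O)c3ccc(C(N)=O)cc3)cccc12`, which carries carbamoyl, gives 15 ug/mL, the higher of the two actual numbers. Compound 2 `N#Cc1c[nH]c2c(NS(=O)(=O)c3ccc(C(=O)O)cc3)cccc12`, which carries carboxy, gives only a limit, > 100 ug/mL.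

Every change at this place has mattered so far. Carboxy in place of methoxy gave an at least 71-fold higher number from compound 1 to compound 2 (1.85 log units; beyond the scatter). Carbamoyl in place of methoxy gave an 11-fold higher number from compound 1 to compound 3 (1.03 log units; beyond the scatter), and amino in place of hydroxy on the carbonyl carbon gave an at least 6.6-fold lower number from compound 2 to compound 3 (0.82 log units; beyond the scatter).

Compound 4 `N#Cc1c[nH]c2c(NS(=O)(=O)c3ccc(N)cc3)cccc12` has amino in place of carbamoyl on an aromatic carbon. Among the measured compounds shown here, no measured step makes this exact swap, so the forecast is uncertain. Still, compound 4 gives up the carbamoyl group, and bringing that group in for methoxy meant an 11-fold higher number from compound 1 to compound 3 (1.03 log units; beyond the scatter). A clear move back towards compound 1 therefore seems likely, though not necessarily all the way. The expected change in this assay is a 5.0-fold lower number from compound 3 to compound 4 (0.70 log units; beyond the scatter), a step to a lower number and beyond the scatter. Compound 4 is estimated at 3 ug/mL, with an expected range from 0.6 ug/mL to 15 ug/mL.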

Compound 4, half-maximal inhibitory concentration: 4.4 ug/mL
The estimate for compound 4 lay 1.5-fold (0.17 log units) below the measured number; the measured number falls inside the stated range.
By their numbers in this assay, from the lowest: compound 1; then compound 4; then compound 3. At a limit, above all of these: compound 2.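

In this assay amino on this aromatic carbon, para to a large group, recovers part of what carbamoyl lost, giving a 3.4-fold lower number from compound 3 to compound 4 (0.53 log units; beyond the scatter) but methoxy keeps the lowest number of the four, with a 3.1-fold higher number from compound 1 to compound 4 (0.50 log units; beyond the scatter) still left as a gap. Carbamoyl and amino are counted alike, each with 1 hydrogen-bond donor, 1 hydrogen-bond acceptor and no net charge, so these counts do not separate them, although 3 heavy atoms leave and only 1 enters and the step between them lies beyond the scatter. The widest gap involving compound 4 is an at least 22-fold lower number from compound 2 to compound 4 (1.35 log units; beyond the scatter) and it rests on a limit for compound 2 rather than on a true number: the limit of > 100 ug/mL in this assay, at which 1 of the 4 values shown sits.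

From the compounds shown here alone, whether a hydroxyl group or a dimethylamino group on this carbon would match methoxy or even improve on it stays open. The numbers also do not say why amino and methoxy differ, so the gap between them remains a measured fact without an explanation.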